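From thiophen-3-yl to furan-2-yl in a cytotoxic series

This account rests on a few compounds, and the source may have more. Where it says the series, first, only, none or still open, it means among the compounds named here.

Within the data shown here, in a functional assay on HL-60 cells (Homo sapiens) for cytotoxicity, read by ELISA, with a stated time of 2 days (a lower number here means a stronger inhibitor, a higher number a weaker inhibitor), compound 2 (`Oc1ccc(-c2cc(-c3ccccc3)cc(-c3ccsc3)n2)cc1`) gives 3600 nM and holds the lower of the two numbers known so far. Compound 1 (`Oc1cccc(-c2cc(-c3ccccc3)cc(-c3ccco3)n2)c1`) gives 9910 nM in that measurement, and the gap between the two lies beyond the usual scatter. Compound 3 (`Oc1ccc(-c2cc(-c3ccccc3)cc(-c3ccco3)n2)cc1`) keeps the 4-hydroxyphenyl group of compound 2 but has furan-2-yl in place of thiophen-3-yl on an aromatic carbon. Among the measured compounds shown here, no measured pair shows this exchange alone, so its size in this assay remains uncertain. A small move toward a higher number is expected, since compound 1 gives 9910 nM while also carrying furan-2-yl. The estimated step is a 1.4-fold higher number from compound 2 to compound 3 (0.14 log units; within the scatter) and may stay within the scatter. For compound 3 the estimate is 5000 nM with an expected range from 1800 nM to 14000 nM in this read-out.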

Compound 3, half-maximal inhibitory concentration: 3300 nM
Estimate against measurement, compound 3: 1.5-fold (0.18 log units) above; the range from low to high includes it.
By their numbers in this assay, from the lowest: compounds 3 and 2 (each within the scatter of the next); then compound 1.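

In this assay, the exchange of thiophen-3-yl for furan-2-yl next to the ring nitrogen gives a 1.1-fold lower number from compound 2 to compound 3 (0.04 log units; within the scatter), so these two five-membered rings cannot be told apart at this position. With furan-2-yl held fixed, 4-hydroxyphenyl in place of 3-hydroxyphenyl gives a 3.0-fold lower number from compound 1 to compound 3 (0.48 log units; beyond the scatter), which makes the place of the hydroxyl group, and not the choice between these two rings, the change that moves the number in this pair. Nothing available explains either result.

On these data alone, whether an amine or a longer chain at the carbon next to the ring nitrogen would also leave the number within the scatter remains open. As far as these compounds go, it is also open whether the step from 3-hydroxyphenyl to 4-hydroxyphenyl holds with thiophen-3-yl, and what a methoxy group in place of the hydroxyl group would do.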